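The source may report more compounds than this note shows. Statements on the series, on what has been measured and on what is new or still open speak of the compounds shown alone.

Measured so far:
Compound 1, `CN1C=CN(C2NC(C(Cl)(Cl)Cl)=CN2c2ccc(S(N)(=O)=O)cc2)C=C1`: in a physicochemical assay for lipophilicity (a higher number here means a more lipophilic compound, a lower number a more polar compound), compound 1 gives 2.85.
Compound 2, `CC1=CN(c2ccc(S(N)(=O)=O)cc2)C(N2C=CN(C)C=C2)N1`: in this assay compound 2 gives 1.44.
Compound 3, `CN1C=CN(C2OC(C(Cl)(Cl)Cl)=CN2c2ccc(S(N)(=O)=O)cc2)C=C1`: in this assay compound 3 gives 2.41.

For the measured compounds named here, the one measured step is methyl in place of trichloromethyl on a double-bonded ring carbon, which gave a number 1.41 log units lower from compound 1 to compound 2 (beyond the scatter). Compound 4, `CC1=CN(c2ccc(S(N)(=O)=O)cc2)C(N2C=CN(C)C=C2)O1`, is not yet measured and differs from compound 3 by methyl in place of trichloromethyl on a double-bonded ring carbon. This is the same kind of change, not the same: in compound 1 the site lies on a five-membered non-aromatic ring with 2 nitrogen, next to the ring nitrogen, whereas in compound 3 it lies on a five-membered non-aromatic ring with 1 nitrogen and 1 oxygen, next to the ring oxygen. How the core of compound 3 differs from the core of compound 1 is not broken down here; the two values show compound 3 lower than compound 1. The expected step is a number 1.41 log units lower from compound 3 to compound 4 (beyond the scatter), resting on the measured a number 1.41 log units lower from compound 1 to compound 2 (beyond the scatter). Compound 4 is thus estimated at 1 in this assay, between 0.5 and 1.5.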

Compound 4, partition coefficient: 1.04
The estimate for compound 4 lay 0.04 log units below the measured number; low and high end bracket the measured number.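

In this assay, methyl in place of trichloromethyl on a double-bonded ring carbon gave a number 1.37 log units lower from compound 3 to compound 4 (beyond the scatter) and, on the core of compound 1, the same kind of change gave a number 1.41 log units lower from compound 1 to compound 2 (beyond the scatter) in the earlier pair. Both steps are large and run in the same direction, so the change carried over from the core of compound 1 to the core of compound 3, although this rests on just two pairs and does not show that it would hold on any other core or for any other pair of groups. Nothing at hand gives a reason for the size of either step.

Only trichloromethyl and methyl appear at this place in the compounds shown, which leaves open where trifluoromethyl, an amine or a carboxylic acid would fall on either core. Also open, going by these compounds, is whether a step of this kind would appear on a third core.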